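Swapping the tetrazolyl thioether of compound 1 for a heteroaryl ether

A few compounds are considered here, and "the series" means these few. Any claim that something is new, unique, unknown or untested is made for them only; others in the source may bear on it.

The measured compounds in a functional assay on Jurkat cells (Homo sapiens) for inhibition; on this read-out lower numbers stand for stronger inhibition and higher numbers for weaker inhibition:
Compound 1 `CC(C)[C@H](NC(=O)COc1cccc2ccccc12)C(=O)N[C@@H](CC(=O)O)C(=O)CSc1nnnn1-c1ccccc1` gives 153000 nM.
Compound 2 `CC(C)[C@H](NC(=O)COc1cccc2ccccc12)C(=O)N[C@@H](CC(=O)O)C(=O)CSc1nc2ccccc2[nH]1` reaches only a limit of the assay, > 200000 nM.
Compound 3 `CC(C)[C@H](NC(=O)COc1cccc2ccccc12)C(=O)N[C@@H](CC(=O)O)C(=O)COc1ccc2ccccc2n1` likewise reaches only a limit of the assay, > 200000 nM.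

For the measured compounds named here, compound 1 thus stands as the only actual number among the three; the other two values are limits, and the limit of > 200000 nM in this assay, at which 2 of the 3 values shown sit, marks where two of the three values sit. The two steps away from compound 1 both change the group on a saturated chain carbon bound to a carbonyl carbon: an at least 1.3-fold higher number from compound 1 to compound 2 (0.11 log units; that floor lies within the scatter) and an at least 1.3-fold higher number from compound 1 to compound 3 (0.11 log units; that floor lies within the scatter). Between compound 2 and compound 3 the step is a step that the two limits leave unreadable from compound 2 to compound 3.

Compound 4 `CC(C)[C@H](NC(=O)COc1cccc2ccccc12)C(=O)N[C@@H](CC(=O)O)C(=O)COc1[nH]cnc2nncc1-2` carries another change at the same place: a group of 10 heavy atoms (5 carbon, 4 nitrogen, 1 oxygen; one five-membered aromatic ring with 2 hetero atoms, one six-membered aromatic ring with 2 hetero atoms) in place of a group of 12 heavy atoms (7 carbon, 4 nitrogen, 1 sulfur; one five-membered aromatic ring with 4 hetero atoms, one six-membered aromatic ring of carbon only), on a saturated chain carbon bound to a carbonyl carbon. Both measured replacements of the tetrazolyl thioether of compound 1 led to a weaker or, within the scatter, unchanged reading, so the same is expected here. Compound 4 is therefore estimated at 200000 nM in this assay, between 100000 nM and 400000 nM, which is expected to mean a 1.3-fold higher number from compound 1 to compound 4 (0.12 log units; within the scatter), with a real chance that only a limit is reported.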

Compound 4, half-maximal inhibitory concentration: 161000 nM
The estimate for compound 4 lay 1.2-fold (0.09 log units) above the measured number; the range from low to high includes it.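

In this assay, replacing the sulfur-linked (1-phenyl-1H-tetrazol-5-yl)sulfanyl group with a smaller oxygen-linked group that carries one hydrogen-bond donor gives a 1.1-fold higher number from compound 1 to compound 4 (0.02 log units; within the scatter), so at this place neither the sulfur nor the tetrazole ring is needed to keep a measurable reading. Compound 2 and compound 3 remain limits of the assay rather than numbers: the limit of > 200000 nM in this assay, at which 2 of the 4 values shown sit.

Against those limits, the new oxygen-linked group gives an at least 1.2-fold lower number from compound 3 to compound 4 (0.09 log units; that floor lies within the scatter), and likewise an at least 1.2-fold lower number from compound 2 to compound 4 (0.09 log units; that floor lies within the scatter), so no real gain over either compound can be claimed.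

Every step shown here either stays within the scatter or ends at a limit, which leaves open whether any group on this saturated chain carbon bound to a carbonyl carbon can move the reading by a clear margin. A plain phenoxy group, a phenoxy group carrying fluorine atoms or an amine at the same place could test this, as the groups shown are all built on aromatic rings containing nitrogen.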